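Extending the Acid Chain from Compound 3 to Compound 4

The compounds below may be only part of what the source reports. "The series", "measured", "known", "first", "only" and "open" are said of these compounds alone.

Compound 1 `O=C(O)CCCCCn1nc(-c2ccccc2)c(-c2ccccc2)c1-c1ccccc1` carries an acid-ended saturated chain attached to an aromatic nitrogen of its core. Compound 2 `O=C(O)CCCCCCn1nc(-c2ccccc2)c(-c2ccccc2)c1-c1ccccc1` is the same molecule with a longer chain. Compound 3 `O=C(O)CCCCCCCCn1cc(-c2ccccc2)c(-c2ccccc2)n1` has a different core and a longer chain still, and compound 4 `O=C(O)CCCCCCCCCn1cc(-c2ccccc2)c(-c2ccccc2)n1` lengthens that chain once more. All four are judged in a functional assay for inhibition, with Homo sapiens as the target; a higher number here means a weaker inhibitor, a lower number a stronger inhibitor.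

Compound 1 gives > 78000 nM, which is a limit of the assay and not a number (the limit of > 78000 nM in this assay, at which 1 of the 3 values shown sits). Compound 2 gives 22400 nM. Compound 3 gives 4500 nM, the lowest of the two measured numbers. The change carboxymethyl in place of carboxy on a saturated chain carbon, five bonds along the chain from an aromatic nitrogen brought an at least 3.4-fold lower number from compound 1 to compound 2 (0.54 log units; beyond the scatter). How the core of compound 3 differs from the core of compound 1 is not broken down here.

Compound 4 differs from compound 3 by carboxymethyl in place of carboxy on a saturated chain carbon, eight bonds along the chain from an aromatic nitrogen, the same kind of change as between compound 1 and compound 2, though the place differs: five bonds along the chain from an aromatic nitrogen in the earlier pair, eight bonds here. Because the earlier step was an at least 3.4-fold lower number from compound 1 to compound 2 (0.54 log units; beyond the scatter), a smaller gain is expected here. The estimated step is a 1.8-fold lower number from compound 3 to compound 4 (0.26 log units; within the scatter). Compound 4 is therefore estimated at 2500 nM, expected to fall between 900 nM and 7000 nM.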

Compound 4, half-maximal inhibitory concentration: > 81000 nM
Compound 4 gave a limit, no number; the forecaster's own chance of this, stated with the estimate: 5%; middle value at least 32-fold (1.51 log units) from the limit.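

Carried to the other core, the same one-carbon lengthening went the opposite way in this assay, bringing an at least 18-fold higher number from compound 3 to compound 4 (1.25 log units; beyond the scatter). The two steps are too far apart to treat this change as having one fixed effect that transfers between the cores: the same change on two cores in this assay, an at least 3.4-fold lower number (0.54 log units; beyond the scatter) from compound 1 to compound 2 and an at least 18-fold higher number (1.25 log units; beyond the scatter) from compound 3 to compound 4, at least 62-fold (1.79 log units) apart, beyond the scatter of two such steps

Going by these compounds, compound 4 gives > 81000 nM, which is a limit of the assay and not a number; the true size of the step stays unknown, and with the change sitting five bonds along the chain from an aromatic nitrogen in one pair and eight bonds along in the other, these pairs cannot separate the effect of the core from the effect of the place.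

Open, on these data alone, is how a shorter chain on the core of compound 3, or a longer chain on the core of compound 1, would behave, which would help to tell core and chain length apart. Also open is whether the same jump would appear with an amide or an ester at the chain end, since neither is among the compounds shown.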